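A few compounds are considered here, and "the series" means these few. Any claim that something is new, unique, unknown or untested is made for them only; others in the source may bear on it.

In a functional assay on MCF7 cells (Homo sapiens) for antiproliferative activity, read by MTT assay, with a stated time of 72 h (a lower number here means a stronger inhibitor, a higher number a weaker inhibitor), compound 3 `O=C(N/N=C/c1ccco1)c1cccc(S(=O)(=O)N2CCOCC2)c1` gives > 100000 nM, which is a limit of the assay rather than a number. Compound 1 `C/C(=N\NC(=O)c1cccc(S(=O)(=O)N2CCOCC2)c1)c1ccc(O)cc1` gives > 100000 nM, also a limit. Compound 2 `C/C(=N\NC(=O)c1cccc(S(=O)(=O)N2CCOCC2)c1)c1cc(O)ccc1O` gives > 100000 nM, a limit as well. Among the measured compounds shown here, the one measured step, a step that the two limits leave unreadable from compound 1 to compound 2, cannot be read, since the limit of > 100000 nM in this assay, at which 3 of the 3 values shown sit, holds all three values shown. Compound 4 `CCOc1cccc(/C=N/NC(=O)c2cccc(S(=O)(=O)N3CCOCC3)c2)c1O` differs from compound 3 by 3-ethoxy-2-hydroxyphenyl in place of furan-2-yl on a carbon with a double bond to nitrogen. For the measured compounds named here, no measured step covers a change of this kind, and three limits give no footing for a direction. A step that the limit leaves unreadable from compound 3 to compound 4 is expected, meaning no shift that could be read. Compound 4 is therefore estimated at 150000 nM, with a range from 40000 nM to 600000 nM, and most likely only a limit will again be reported.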

Compound 4, half-maximal inhibitory concentration: 19300 nM
Compound 4: middle estimate off by 7.8-fold (0.89 log units), on the high side; the measured number lies below the stated range.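

Replacing furan-2-yl with 3-ethoxy-2-hydroxyphenyl on the carbon with a double bond to nitrogen gives, in this assay, an at least 5.1-fold lower number from compound 3 to compound 4 (0.71 log units; beyond the scatter). Among the compounds shown here, this position can therefore bring a compound off the limit, which no earlier compound showed. The true size of the step stays unknown because compound 3 has only a limit: the limit of > 100000 nM in this assay, at which 3 of the 4 values shown sit.

The whole ring changes in one step, leaving open whether the hydroxy group, the ethoxy group or the ring itself matters. On these data alone, how a butoxy chain or an amine on this ring would read also remains open.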